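Furan in place of pyridine on a shared pyridine-carbon core

The compounds below may be only part of what the source reports. "The series", "measured", "known", "first", "only" and "open" are said of these compounds alone.

Measured compounds in a functional assay on T47D cells (Homo sapiens) for cytotoxicity, read by CCK-8 assay and cell counting, with a stated time of 2 days; on this read-out higher numbers stand for weaker inhibition and lower numbers for stronger inhibition:
Compound 1, `Oc1ccc(-c2cc(-c3cccc(Cl)c3)nc(-c3ccccn3)c2)cc1`: 27900 nM
Compound 2, `Oc1cccc(-c2cc(-c3ccc(Cl)cc3)nc(-c3ccco3)c2)c1`: 10500 nM
Compound 3, `Oc1cccc(-c2cc(-c3ccncc3)nc(-c3ccccc3Cl)c2)c1`: "not determined" (no result reported)

Compound 3 stands nowhere on the numbers shown: its run in this assay gave no result, so there is no value to set a step against. Compound 4, `Oc1cccc(-c2cc(-c3ccco3)nc(-c3ccccc3Cl)c2)c1`, differs from compound 3 in one place, (furan-2-yl in place of pyridin-4-yl on an aromatic carbon). For the measured compounds named here, with no number for compound 3, no step can be sized; any expectation for compound 4 rests only on compound 1 and compound 2, both weak in this assay. Compound 2, which also carries the furan-2-yl and the 3-hydroxyphenyl, gives 10500 nM in this assay. Compound 4 is therefore expected near 15000 nM, within 4000 nM to 60000 nM.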

Compound 4, half-maximal inhibitory concentration: 2010 nM
Estimate against measurement, compound 4: 7.5-fold (0.87 log units) above; the measured number lies below the stated range.
By their numbers in this assay, from the lowest: compound 4; then compound 2; then compound 1.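

In this assay, for the compounds shown here, with the furan-2-yl and 3-hydroxyphenyl groups held in common, 2-chlorophenyl in place of 4-chlorophenyl gives a 5.2-fold lower number from compound 2 to compound 4 (0.72 log units; beyond the scatter) and is the only step here that can be sized. It shows that the place of the chlorine on that phenyl group alone moves the read-out beyond the scatter. Nothing given here explains this step.

The step from pyridin-4-yl to furan-2-yl cannot be read, since compound 3 has no result. From the compounds shown here alone, whether fluorine or a methoxy group could stand in place of that chlorine also remains open.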